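The source may report more compounds than this note shows. Statements on the series, on what has been measured and on what is new or still open speak of the compounds shown alone.

Going by the values given here, compound 3, with the structure `O=C(Nc1cccc(Br)c1)N[C@H]1CC[C@H](Oc2ccc(F)cc2)CC1`, is the only member of this small set to give a number at all: in a functional assay on CRL2813 cells (Homo sapiens) for cytotoxicity, read by sulforhodamine B assay, with a stated time of 5 days (a higher number here means a weaker inhibitor, a lower number a stronger inhibitor), compound 3 gives 6200 nM. Compound 1, `CSc1ccccc1NC(=O)N[C@H]1CC[C@H](Oc2ccc(F)cc2)CC1`, reaches only the limit of this assay, with > 20000 nM. Compound 2, `O=C(Nc1ccc(Cl)cc1)N[C@H]1CC[C@H](Oc2ccc(F)cc2)CC1`, likewise sits at the limit, with > 20000 nM. The steps of an at least 3.2-fold lower number from compound 1 to compound 3 (0.50 log units; beyond the scatter) and an at least 3.2-fold lower number from compound 2 to compound 3 (0.50 log units; beyond the scatter) are therefore read against (the limit of > 20000 nM in this assay, at which 2 of the 3 values shown sit), and the step that the two limits leave unreadable from compound 1 to compound 2.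

Compound 4, `O=C(Nc1ccccc1Cl)N[C@H]1CC[C@H](Oc2ccc(F)cc2)CC1`, is the next variation, carrying (2-chlorophenyl in place of 3-bromophenyl on an amide-type nitrogen). The bearing steps both show that moving away from 3-bromophenyl in either tested direction, to 2-(methylsulfanyl)phenyl or to 4-chlorophenyl, lost at least a modest amount; a 2-chlorophenyl group is a third departure from the one substitution pattern that gave a number. He therefore expects compound 4 to be weaker than compound 3, by an estimated 2.4-fold higher number from compound 3 to compound 4 (0.38 log units; beyond the scatter), quite possibly back at the limit. His estimate for compound 4 in this assay is 15000 nM, within 5000 nM to 40000 nM.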

Compound 4, half-maximal inhibitory concentration: 9100 nM
Estimate against measurement, compound 4: 1.6-fold (0.22 log units) above; measured number inside the range.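

In this assay, going by these compounds alone, 3-bromophenyl is no longer the only group on the amide-type nitrogen to give a number, and a 1.5-fold higher number from compound 3 to compound 4 (0.17 log units; within the scatter) does not separate it from 2-chlorophenyl. Where the chloro group sits on the phenyl ring matters, as 2-chlorophenyl in place of 4-chlorophenyl gives an at least 2.1-fold lower number from compound 2 to compound 4 (0.34 log units; beyond the scatter), while chloro in place of methylsulfanyl on an aromatic carbon gives an at least 2.1-fold lower number from compound 1 to compound 4 (0.34 log units; beyond the scatter). Both of these steps are read against a limit rather than a number: the limit of > 20000 nM in this assay, at which 2 of the 4 values shown sit.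

On these data alone, what 3-chlorophenyl or 2-bromophenyl would give on the same nitrogen stays open, so the halogen and its place on the ring cannot yet be told apart. Also open, as far as these compounds go, is whether an unsubstituted phenyl, or a phenyl carrying a methoxy group or a nitrile, would give a number at all.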